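Swapping 3-chloro-4-fluorophenyl for 3-chloro-2-fluorophenyl on a shared core

The source may hold more compounds than are shown below. What is called first, only, known or untested is meant among the compounds shown, and "the series" means these compounds.

Of the compounds shown here, three sharing a core have so far been tested in a functional assay on HepG2 cells (Homo sapiens) for antiproliferative activity, read by MTT assay, with a stated time of 48 h (on this read-out lower numbers stand for stronger inhibition and higher numbers for weaker inhibition), for their effect on these cells. Compound 1 (`O=C(/C=C/c1ccc(O)cc1)Nc1cc2c(Nc3ccc(Cl)c(Cl)c3)ncnc2s1`) comes in at 42900 nM and compound 2 (`O=C(/C=C/c1ccccc1)Nc1cc2c(Nc3ccc(F)c(Cl)c3)ncnc2s1`) at 22800 nM and compound 3 (`N#Cc1cccc(Nc2ncnc3cc(NC(=O)/C=C/c4ccccc4)sc23)c1`) at 15900 nM on the same read-out. Compound 2 lies within the scatter of both other compounds, so its number cannot be firmly ranked against either of them.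

Compound 4 (`O=C(/C=C/c1ccccc1)Nc1cc2c(Nc3cccc(Cl)c3F)ncnc2s1`) has not yet been measured. It holds the same atoms as compound 2, joined differently. The change is 3-chloro-2-fluorophenyl in place of 3-chloro-4-fluorophenyl on a nitrogen on an aromatic ring and it falls on a nitrogen on an aromatic ring. Within the data shown here, no measured pair in this set differs in one place only, so the data show no direct precedent for this swap. The expectation rests on compound 2 at 22800 nM and compound 3 at 15900 nM. These two values stay within the scatter of each other even though the groups on that nitrogen differ. In this assay the estimated 1.1-fold lower number from compound 2 to compound 4 (0.04 log units; within the scatter) is expected to stay within the scatter, with no direction favoured. Compound 4 is estimated at 21000 nM with an expected range from 9000 nM to 50000 nM as its likely span.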

Compound 4, half-maximal inhibitory concentration: 44600 nM
Compound 4: middle estimate off by 2.1-fold (0.33 log units), on the low side; the measured number falls inside the stated range.
By their numbers in this assay, from the lowest: compounds 3, 2, 1 and 4 (each within the scatter of the next, the first and the last beyond it).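

Among these compounds, compound 2 and compound 4 form the first pair in this set that differs in one place only, so the swap to 3-chloro-2-fluorophenyl from 3-chloro-4-fluorophenyl on a nitrogen on an aromatic ring can now be read directly in this assay, as a 2.0-fold higher number from compound 2 to compound 4 (0.29 log units; within the scatter). This step lies within the scatter, so the two phenyl groups, built from the same atoms joined differently, cannot be firmly ranked at this position, and this single pair sets no direction for the change. No measurement at hand offers an explanation for the number of compound 4.

The compounds shown leave open whether a larger change on this phenyl group, such as a methoxy group or an amine in place of the fluorine, would give a step beyond the scatter. They also leave open whether the same swap would give a similar step with the hydroxy-bearing phenyl group of compound 1 on the amide side, or with a carboxylic acid on that phenyl group.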